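The source may report more compounds than this note shows. Statements on the series, on what has been measured and on what is new or still open speak of the compounds shown alone.

Compound 1 `CCOc1cc2[nH]c(Cc3nn(CC(=O)O)c(=O)c4ccccc34)nc2cc1Cl` is measured in a functional assay on CHO cells for antagonist activity at sphingosine 1-phosphate receptor 2 (Homo sapiens), read by GTPgammaS binding (a lower number here means a stronger inhibitor, a higher number a weaker inhibitor), where compound 1 gives 109 nM. Compound 2 `O=C(O)Cn1nc(Cn2cc3cc(OCC4CC4)c(Cl)cc3n2)c2ccccc2c1=O` gives 53 nM in this assay, and compound 3 `C[C@H](C(=O)O)n1nc(Cn2cc3cc(OCC4CC4)c(Cl)cc3n2)c2ccccc2c1=O` gives 15 nM. The difference between the core of compound 1 and the core of compound 3 is not broken down here. Between compound 3 and compound 2 the change is hydrogen in place of methyl on a saturated chain carbon bound to an aromatic nitrogen and a carbonyl carbon, and it brings a 3.5-fold higher number from compound 3 to compound 2 (0.55 log units; beyond the scatter).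

Compound 4 `COc1cc2[nH]c(Cc3nn(CC(=O)O)c(=O)c4ccccc34)nc2cc1Cl` has not yet been measured. It differs from compound 1 by hydrogen in place of methyl on a saturated chain carbon bound to an oxygen on an aromatic ring, the same kind of change as the earlier one, though made at a different place: on a saturated chain carbon bound to an oxygen on an aromatic ring, rather than on a saturated chain carbon bound to an aromatic nitrogen and a carbonyl carbon. Resting only on compound 3 giving 15 nM against compound 2 giving 53 nM, the step is expected to be a 1.8-fold higher number from compound 1 to compound 4 (0.26 log units; within the scatter), smaller than the earlier one given the different place. Compound 4 is therefore estimated at 200 nM, within 80 nM to 500 nM.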

Compound 4, half-maximal inhibitory concentration: 241 nM
For compound 4 the middle estimate is 1.2-fold (0.08 log units) below the measured one, and the stated range covers the measured number.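

In this assay, going from ethoxy to methoxy brings a 2.2-fold higher number from compound 1 to compound 4 (0.34 log units; beyond the scatter), the same direction as the earlier loss of a methyl on the other core. The two steps cannot be told apart in size: the same change on two cores in this assay, a 3.5-fold higher number (0.55 log units; beyond the scatter) from compound 3 to compound 2 and a 2.2-fold higher number (0.34 log units; beyond the scatter) from compound 1 to compound 4, 1.6-fold (0.20 log units) apart, within the scatter of two such steps. Among the compounds shown here, this rests on only two pairs, with the methyl at a different place in each, so it shows agreement between these pairs but not that the step carries over to other cores or other places.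

The compounds shown leave open what a longer chain such as propoxy would give on the core of compound 1. They also leave open how an amide in place of the carboxylic acid would behave on either core.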